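Ring Closure at the Sulfonyl Sulfur

A few compounds are considered here, and "the series" means these few. Any claim that something is new, unique, unknown or untested is made for them only; others in the source may bear on it.

Compound 1 `Cc1ccc(S(=O)(=O)N(C)C(C)C)cc1C#Cc1cc(Cl)ccc1OCC(=O)O`: 3.8 nM
Compound 2 `COCCNS(=O)(=O)c1ccc(C)c(C#Cc2cc(Cl)ccc2OCC(=O)O)c1`: 3.6 nM

Both compounds share one core and differ only in the group on the sulfonyl sulfur. In an assay on CHO cells for displacement of a labelled ligand from prostaglandin D2 receptor 2 (Homo sapiens), read by scintillation counting (on this read-out higher numbers stand for weaker inhibition and lower numbers for stronger inhibition), compound 1 gives 3.8 nM. In this assay compound 2 gives 3.6 nM. Within the data shown here, the single measured step, a 1.1-fold lower number from compound 1 to compound 2 (0.02 log units; within the scatter), shows that swapping one amino group for another at this position left the number unchanged within the scatter, so compound 2 and compound 1 stand side by side with no order between them.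

Compound 3 `Cc1ccc(S(=O)(=O)N2CCOCC2)cc1C#Cc1cc(Cl)ccc1OCC(=O)O` carries the change (morpholin-4-yl in place of (2-methoxyethyl)amino on a sulfonyl sulfur). Among the measured compounds shown here, the only step that bears on it is a 1.1-fold lower number from compound 1 to compound 2 (0.02 log units; within the scatter), which was flat. Since a change at the same place produced nothing beyond the scatter, no step beyond the scatter is expected here either, and compound 3 is estimated at 4 nM, in the range 1.5 nM to 11 nM, an expected step of a 1.1-fold higher number from compound 2 to compound 3 (0.05 log units; within the scatter).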

Compound 3, inhibition constant: 3.6 nM
Estimate against measurement, compound 3: 1.1-fold (0.05 log units) above; the measured number falls inside the stated range.
By their numbers in this assay, from the lowest: compounds 2, 3 and 1 (each within the scatter of the next).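

In this assay, closing the group on the sulfonyl sulfur into a ring gives no change at the digits printed from compound 2 to compound 3 (within the scatter) and, set against the branched group, a 1.1-fold lower number from compound 1 to compound 3 (0.02 log units; within the scatter) for the same change. The morpholin-4-yl ring, which carries no hydrogen-bond donor, therefore does as well here as the open (2-methoxyethyl)amino and isopropyl(methyl)amino groups, and all three compounds stand within the scatter of one another with no order among them. Nothing measured here gives a reason for this flat result.

From the compounds shown here alone, all three groups carry no net charge, so it remains open whether a group with a second ring nitrogen, such as piperazin-1-yl, or a chain ending in a carboxylic acid would hold the number. A much longer chain or a bulkier ring on the sulfur is equally untested by the compounds shown.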